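A few compounds are considered here, and "the series" means these few. Any claim that something is new, unique, unknown or untested is made for them only; others in the source may bear on it.

Measured in a functional assay on NCI-H460 cells (Homo sapiens) for cytotoxicity, read by sulforhodamine B assay, with a stated time of 48 h; a lower number here means that less compound is tolerated, a higher number that more compound is tolerated:
compound 1 `Nc1nc(Cl)c2ncn(Cc3ccc(CCl)cc3)c2n1`, 63100 nM
compound 2 `ClCc1cccc(Cn2cnc3c(Cl)nc(Cl)nc32)c1`, a limit of the assay only, > 100000 nM
compound 3 `ClCc1ccc(Cn2cnc3c(Cl)nc(Cl)nc32)cc1`, 28800 nM

Compound 3 and compound 1 differ in one place, (amino in place of chloro on an aromatic carbon), and this change gave a 2.2-fold higher number from compound 3 to compound 1 (0.34 log units; beyond the scatter) in this assay. Compound 2 and compound 3 are built from the same atoms joined differently; the difference between the two cores is not broken down here. Compound 2 sits at the limit of > 100000 nM in this assay, at which 1 of the 3 values shown sits, so its value is a limit, not a number. Compound 4 `Nc1nc(Cl)c2ncn(Cc3cccc(CCl)c3)c2n1` has not yet been measured in this assay; it differs from compound 2 by amino in place of chloro on an aromatic carbon, the same change as from compound 3 to compound 1. On that earlier step, the expected step is a step that the limit leaves unreadable from compound 2 to compound 4, and the estimated value for compound 4 in this assay is 200000 nM, between 70000 nM and 600000 nM.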

Compound 4, concentration lethal to 50% of the cells: 47900 nM
The estimate for compound 4 lay 4.2-fold (0.62 log units) above the measured number; the measured number lies below the stated range.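

In this assay, amino in place of chloro on an aromatic carbon gave an at least 2.0-fold lower number from compound 2 to compound 4 (0.31 log units; beyond the scatter) on this core, so the change did not carry over in the same direction from the other core: the same change on two cores in this assay, a 2.2-fold higher number (0.34 log units; beyond the scatter) from compound 3 to compound 1 and an at least 2.0-fold lower number (0.31 log units; beyond the scatter) from compound 2 to compound 4, at least 4.5-fold (0.66 log units) apart, beyond the scatter of two such steps. Compound 2 stands only at a limit, > 100000 nM, so the full size of this step is not known. These two pairs show that the outcome of the change depended on the core in this small set, but they do not show why, and one pair per core gives no general rule.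

The compounds shown leave open how other groups on that carbon, such as a methylamino group or a hydroxyl, would read in this assay. They also leave open which direction the change would take on further cores.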